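The compounds below may be only part of what the source reports. "The series", "measured", "known", "first", "only" and "open" are said of these compounds alone.

Measured so far:
compound 1, `CCCCCCCCCCc1ccc(-c2noc(C3CCNCC3)n2)cc1`: 66%
compound 2, `CCCCCCCCCCc1ccc(-c2noc([C@@H](N)CCCN)n2)cc1`: 40%

In an assay on HeLa cells for inhibition of sphingosine-1-phosphate transporter SPNS2 (Mus musculus), read by LC-MS, tested at 2 uM (on this read-out higher numbers stand for more inhibition at the one concentration tested (going by the name of the read-out) and lower numbers for less inhibition), compound 2 stands lowest of the two numbers, and the nearest measured neighbour is compound 1, which lies higher by a margin beyond the scatter. Among the measured compounds shown here, the one measured step, a number 26 percentage points lower from compound 1 to compound 2 (beyond the scatter), was a modest drop and concerned 1,4-diaminobutyl in place of piperidin-4-yl on an aromatic carbon.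

Compound 3, `CCCCCCCCCCc1ccc(-c2noc([C@H](CCCCN)NC(C)=O)n2)cc1`, has not been measured. Its change from compound 2 is 1-acetamido-5-aminopentyl in place of 1,4-diaminobutyl on an aromatic carbon. For the measured compounds named here, no measured step concerns an acetamido group, a pentyl chain or this exchange of the diaminobutyl group, so the step to compound 3 cannot be read from the data and only a loose expectation is possible. For compound 3 in this assay the estimate is 35%, with a range from 10% to 60%. The step this implies, a number 5 percentage points lower from compound 2 to compound 3 (within the scatter), is expected to lie within the scatter.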

Compound 3, a percentage reported as inhibition, at one concentration (the size of the read-out at that concentration, not a potency): 40%
Compound 3: middle estimate off by 5 percentage points, on the low side; measured number inside the range.
By their numbers in this assay, from the lowest: compounds 2 and 3 (each within the scatter of the next); then compound 1.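

In this assay, the exchange of 1,4-diaminobutyl for 1-acetamido-5-aminopentyl on the aromatic carbon gave no change at the digits printed from compound 2 to compound 3 (within the scatter), so this position accepts the larger open-chain group, with its acetamido, without a shift beyond the scatter. The second open-chain group also falls short of piperidin-4-yl, with a number 26 percentage points lower from compound 1 to compound 3 (beyond the scatter), which means that among these three compounds only the piperidin-4-yl of compound 1 stands apart, and both open-chain groups lie level with each other. No available evidence explains this outcome.

As far as these compounds go, the acetamido group and the longer chain enter together, so what each contributes alone remains open. Also open, from the compounds shown here alone, is how a smaller ring amine such as pyrrolidin-3-yl, or a carboxylic acid at the chain end, would read at this position.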